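This account rests on a few compounds, and the source may have more. Where it says the series, first, only, none or still open, it means among the compounds named here.

Of the compounds shown here, three have been measured in an assay on a protein complex for inhibition of CDK8/Cyclin C (Homo sapiens), with a stated time of 1 h, tested at 10 uM; a lower number here means less inhibition, a higher number more inhibition at the concentration tested (going by the name of the read-out). Compound 1 `O=C(O)/C=C/c1ccncc1-c1ccc2cc[nH]c2c1` gives 103%. Compound 2 `CN1CCN(C(=O)/C=C/c2ccncc2-c2ccc(F)cc2)CC1` gives 84%, and compound 3 `NC(=O)/C=C/c1ccncc1Br` gives 81%. Among these three numbers compound 2 sits below compound 1, whose reading is higher by a margin that lies beyond the usual scatter of this assay, while the reading of compound 3 falls within the scatter of compound 2, so no order can be drawn between compound 2 and compound 3.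

Compound 4 `COC1CN(C(=O)/C=C/c2ccncc2-c2ccc(F)cc2)C1` is not yet measured in this assay. It differs from compound 2 in one place: 3-methoxyazetidin-1-yl in place of 4-methylpiperazin-1-yl on a carbonyl carbon. Within the data shown here, no pair of measured compounds shows this change, so its effect in this assay is not known from the data in hand. Since compound 2 already gives 84%, and the change exchanges one neutral ring bearing a single hydrogen-bond acceptor for another, compound 4 is expected to stay near compound 2, with a step of a number 4 percentage points lower from compound 2 to compound 4 (within the scatter) that is estimated not to exceed the scatter in either direction. Compound 4 is therefore estimated to give 80% in this assay, with a likely range from 60% to 95%.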

Compound 4, a percentage reported as inhibition, at one concentration (the size of the read-out at that concentration, not a potency): 77%
Compound 4: middle estimate off by 3 percentage points, on the high side, and the stated range covers the measured number.
By their numbers in this assay, from the lowest: compounds 4, 3 and 2 (each within the scatter of the next); then compound 1.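

In this assay, the exchange of 4-methylpiperazin-1-yl for 3-methoxyazetidin-1-yl on a carbonyl carbon gives a number 7 percentage points lower from compound 2 to compound 4 (within the scatter), and this is the only step shown between compounds that differ in one place. At this position, therefore, a six-membered non-aromatic ring with 2 hetero atoms and a four-membered non-aromatic ring with 1 hetero atom give readings that cannot be told apart, and the inhibition at the tested concentration does not depend on keeping the 4-methylpiperazin-1-yl group. Since the read-out is taken at one concentration and is not a potency, this says nothing about how the two compounds would compare at lower concentrations, and no measurement in hand offers an explanation for the result.

The compounds shown leave open whether a dimethylamino group or a longer chain ending in an amine on the same carbonyl carbon would also stay within the scatter of compound 2. They also leave open how the 3-methoxyazetidin-1-yl group would behave on the core of compound 1, which carries a carboxylic acid and gives 103%.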